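A few compounds are considered here, and "the series" means these few. Any claim that something is new, unique, unknown or untested is made for them only; others in the source may bear on it.

In a functional assay on A498 cells (Homo sapiens) for inhibition, read by sulforhodamine B assay, with a stated time of 48 h, tested at 1 uM (a lower number here means a stronger effect, a higher number a weaker effect of the compound at the concentration tested), three compounds have been measured:

Compound 1 `O=C(Nc1cccc(-n2cc(-c3ccncc3)c(-c3cc(O)cc(Cl)c3)n2)c1)Nc1ccc(Cl)c(C(F)(F)F)c1` gives 92%.
Compound 2 `O=C(Nc1cccc(-n2cc(-c3ccncc3)c(-c3cc(O)cc(Cl)c3)n2)c1)Nc1ccc(Cl)c(Cl)c1` gives 75%.
Compound 3 `COc1cc(Cl)cc(-c2nn(-c3cccc(NC(=O)Nc4cc(C(F)(F)F)cc(C(F)(F)F)c4)c3)cc2-c2ccncc2)c1` gives 37%.

Since a lower number means a stronger effect, compound 3 stands at the strong end of this set: its number is the lowest of the three, with compound 2 nearest and compound 1 furthest, and both gaps lie beyond the usual scatter. Compound 4 `COc1cc(Cl)cc(-c2nn(-c3cccc(NC(=O)Nc4cccc(C(F)(F)F)c4)c3)cc2-c2ccncc2)c1` is the next compound to be tested in this assay. It differs from compound 3 in one place: hydrogen in place of trifluoromethyl on an aromatic carbon. Within the data shown here, the only measured step among the three compounds is a number 17 percentage points lower from compound 1 to compound 2 (beyond the scatter), where one group on an aromatic carbon is swapped for another rather than removed, so it bears on the new step only loosely. Among the measured compounds shown here, compounds 1 and 2 differ from compound 3 in more than one place, and their values show only that compound 3 carries the lowest number. Taking the trifluoromethyl away is expected to weaken the effect, so the number for compound 4 is expected to rise by a number 23 percentage points higher from compound 3 to compound 4 (beyond the scatter). Compound 4 is therefore estimated at 60%, with a range from 35% to 85%.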

Compound 4, a percentage reported as activity, at one concentration (the size of the read-out at that concentration, not a potency): 75%
Estimate against measurement, compound 4: 15 percentage points below, within the range that was stated.
By their numbers in this assay, from the lowest: compound 3; then compounds 2 and 4 (each within the scatter of the next); then compound 1.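

In this assay, taking one trifluoromethyl off an aromatic carbon and leaving hydrogen gives a number 38 percentage points higher from compound 3 to compound 4 (beyond the scatter), a large step, so the effect at the tested concentration depends strongly on what sits at this position. The earlier step only exchanged one group for another, whereas this one shows what happens when the group is removed outright; the trifluoromethyl that remains on the ring, meta to this position, does not keep the number at its lower level. No measurement shown here explains why the number moves so far.

Going by these compounds, whether a single fluorine, a methyl or a nitrile at this position would keep any of the effect remains open. So does whether the same removal would matter as much in a compound with a hydroxy group in place of the methoxy.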